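From 4-fluorophenyl to 3-bromophenyl in a cell assay

The compounds below may be only part of what the source reports. "The series", "measured", "known", "first", "only" and "open" are said of these compounds alone.

In a functional assay on MDA-MB-436 cells (Homo sapiens) for antiproliferative activity, read by MTT assay, with a stated time of 24 h (a lower number here means a stronger inhibitor, a higher number a weaker inhibitor), compound 1 `O=C(O)CC(NC(=O)c1ccc(Cl)cc1Cl)c1ccccc1` gives 78200 nM as its reading, and compound 3 `O=C(O)CC(NC(=O)c1ccc(F)cc1)c1ccc(Cl)cc1Cl` gives 55800 nM as its reading. Among the measured compounds shown here, these two numbers lie within the scatter of each other, so compound 3 stands level with compound 1, the only other compound here with a number. Compound 2 `COc1ccccc1S(=O)(=O)NC(CC(=O)O)c1ccc(C(C)(C)C)cc1` returns > 100000 nM which is a limit of the assay and not a number.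

Compound 4 `O=C(O)CC(NC(=O)c1cccc(Br)c1)c1ccc(Cl)cc1Cl` has not yet been measured. It differs from compound 3 by a single change 3-bromophenyl in place of 4-fluorophenyl on a carbonyl carbon with 3-bromophenyl in place of 4-fluorophenyl on a carbonyl carbon. For the measured compounds named here, no measured pair in this set differs in one place, so no step size can be read directly from this assay and the expectation has little to rest on. Going by the values given here, the only guide is that compound 1 at 78200 nM and compound 3 at 55800 nM sit close together. The estimated step of a 1.1-fold lower number from compound 3 to compound 4 (0.05 log units; within the scatter) is expected to stay within the scatter, with no direction favoured. For compound 4 the estimate is 50000 nM as the expected value and 20000 nM to 100000 nM as its expected range.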

Compound 4, half-maximal inhibitory concentration: > 100000 nM
Compound 4: only a limit was reported; the forecaster's own chance of this, stated with the estimate: 15%; middle value at least 2.0-fold (0.30 log units) from the limit.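

In this assay, among the compounds shown here, the swap of 4-fluorophenyl for 3-bromophenyl, on a carbonyl carbon whose other neighbours are amide-type nitrogen, gives an at least 1.7-fold higher number from compound 3 to compound 4 (0.25 log units; that floor lies within the scatter) as the first step in this set between compounds that differ in one place. Compound 4 reads > 100000 nM as a limit of the assay and not a number. The floor of the step lies within the scatter, so the swap cannot be said to weaken the compound, and the true size of the step stays unread because the readings stop at a ceiling: the limit of > 100000 nM in this assay, at which 2 of the 4 values shown sit.

The change replaces the halogen and alters its ring number at once, so the compounds shown leave open whether a 3-fluorophenyl or a 4-bromophenyl group on this carbonyl carbon would read nearer to compound 3 or to compound 4. They also leave open whether an amine or a carboxylic acid on this ring would give a clear number in this assay and so allow a step beyond the scatter to be read at this position.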